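A Bromine-Bearing Thiophene Swap and Cell Toxicity

The compounds below may be only part of what the source reports. "The series", "measured", "known", "first", "only" and "open" are said of these compounds alone.

Compound 1 `O=C(/C=C/c1ccc(N2CCCCC2)cc1)c1ccc(Cl)s1`, in an ADME assay on PBMC cells (Homo sapiens) for cytotoxicity, with a stated time of 5 days; a higher number here means a weaker inhibitor, a lower number a stronger inhibitor: > 100000 nM, a limit of the assay and not a number.
Compound 2 `c1cc(C2=NNC(c3ccc(N4CCCCC4)cc3)C2)cs1`, in this assay: > 100000 nM, likewise a limit.

Going by the values given here, compound 2 thus stands only at a limit, and the one further value shown is also a limit; the whole picture is the limit of > 100000 nM in this assay, at which 2 of the 2 values shown sit. Compound 3 `Brc1ccsc1C1=NNC(c2ccc(N3CCCCC3)cc2)C1` differs from compound 2 by 3-bromothiophen-2-yl in place of thiophen-3-yl on a carbon with a double bond to nitrogen. Among the compounds with values here, no step between measured compounds exists here, so the step that the limit leaves unreadable from compound 2 to compound 3 is expected to be none beyond the usual scatter. Compound 3 is therefore expected to give about 150000 nM, from 50000 nM to 500000 nM, most likely reported again only as a limit.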

Compound 3, half-maximal inhibitory concentration: 57000 nM
Estimate against measurement, compound 3: 2.6-fold (0.42 log units) above; the measured number falls inside the stated range.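

Putting 3-bromothiophen-2-yl in place of thiophen-3-yl gives an at least 1.7-fold lower number from compound 2 to compound 3 (0.24 log units; that floor lies within the scatter). Going by these compounds alone, compound 3 is the first compound here with a true number in this assay, so a change at this carbon can bring the read-out into the measurable range. The real size of the step stays hidden, since the other values are limits: the limit of > 100000 nM in this assay, at which 2 of the 3 values shown sit.

Going by these compounds, it remains open whether the bromine or the shift in the thiophene's point of attachment matters, as both change at once. A plain thiophen-2-yl, or a methyl or an amine in place of the bromine, would separate the two.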